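Adding a methyl group to compound 3

The compounds below may be only part of what the source reports. "The series", "measured", "known", "first", "only" and "open" are said of these compounds alone.

In a functional assay on OVCAR-3 cells (Homo sapiens) for inhibition, read by sulforhodamine B assay, with a stated time of 48 h (on this read-out higher numbers stand for weaker inhibition of growth and lower numbers for stronger inhibition of growth), compound 3 (`CC(C)(C)NCc1c(C(=O)O)nn(-c2ccccc2)c1-c1ccccc1`) gives only a limit, > 716000 nM. Compound 2 (`CC(C)(C)NCc1c(C(=O)O)nn(-c2ccccc2)c1-c1ccc(Br)cc1`) also gives only a limit, > 585000 nM. Among the compounds with values here, the one measured step, a step that the two limits leave unreadable from compound 2 to compound 3, therefore offers no size to carry forward. Compound 1 (`CCOC(=O)c1nn(-c2ccccc2)c(-c2ccc(C)cc2)c1CNC(C)(C)C`) has entries that disagree, 54 nM; > 585000 nM (2 entries). Compound 4 (`Cc1ccc(-c2c(CNC(C)(C)C)c(C(=O)O)nn2-c2ccccc2)cc1`) differs from compound 3 by methyl in place of hydrogen on an aromatic carbon. With no readable step to go on, no change beyond the scatter is expected, and the expected step is an at least 1.0-fold lower number from compound 3 to compound 4 (0.01 log units; that floor lies within the scatter). A limit is again the likely report. For compound 4 the estimate is 690000 nM, with an expected range of 200000 nM to 720000 nM.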

Compound 4, concentration for 50% growth inhibition: 283000 nM
Compound 4: the middle estimate sits 2.4-fold (0.39 log units) above what was measured; measured number inside the range.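

With methyl on this aromatic carbon, this assay gives the first readable change at this position among the carboxylic acids shown: an at least 2.5-fold lower number from compound 3 to compound 4 (0.40 log units; beyond the scatter). Methyl in place of bromo gives an at least 2.0-fold lower number from compound 2 to compound 4 (0.31 log units; beyond the scatter). Methyl thus separates from both hydrogen and bromo, while the step between those two cannot be read, and both new steps are only minimum sizes.

Going by these compounds, whether ethyl or methoxy at this place would lower the number further stays open. The comparison of compound 4 with its ethyl ester, compound 1, also remains unsettled: the several entries of compound 1 in this assay, 54 nM; > 585000 nM (2 entries)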